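Diethylcarbamoyl in place of tert-butoxycarbonyl on a conjugated dienoate

The source may hold more compounds than are shown below. What is called first, only, known or untested is meant among the compounds shown, and "the series" means these compounds.

Compound 1 `CC(/C=C/CC(C)CCCC(C)C)=C\C(=O)OC(C)(C)C` gives 7.56 in a physicochemical assay for lipophilicity (a higher number here means a more lipophilic compound, a lower number a more polar compound), the highest of the three measured numbers. Compound 2 `COC(C)(C)CCCC(C)C/C=C/C(C)=C/C(=O)OC(C)(C)C` gives 6.36 in this assay, and compound 3 `CC(/C=C/CC(C)CCCC(C)(C)Cl)=C\C(=O)OC(C)C` gives 6.85 in this assay. Among the compounds with values here, the only single-point step measured so far is a number 1.20 log units lower from compound 1 to compound 2 (beyond the scatter); compound 3 differs from compound 1 in more than one place, so its value shows only that it lies lower than compound 1 by more than the scatter.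

Compound 4 `CCN(CC)C(=O)/C=C(C)/C=C/CC(C)CCCC(C)C` differs from compound 1 in this way: diethylamino in place of tert-butoxy on a carbonyl carbon. Within the data shown here, no measured step bears directly on this change, because neither the methoxy step nor the values of compound 3 touch the carbonyl end of the chain. The author therefore expects the step of a number 1.36 log units lower from compound 1 to compound 4 (beyond the scatter) from compound 1 to compound 4 to be a decrease beyond the scatter, on the basis of the replacement of an ester oxygen by an amide nitrogen, but with little support from the numbers at hand. Compound 4 is estimated at 6.2, within a range of 5.5 to 6.9.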

Compound 4, partition coefficient: 6.02
Compound 4: the middle estimate sits 0.18 log units above what was measured, and the stated range covers the measured number.
By their numbers in this assay, from the lowest: compound 4; then compound 2; then compound 3; then compound 1.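

Diethylamino in place of tert-butoxy on a carbonyl carbon gives a number 1.54 log units lower from compound 1 to compound 4 (beyond the scatter) in this assay, so this position responds strongly to the change, which the methoxy step on the saturated chain could not show. The number falls even though the heavy-atom count of the group stays the same and neither group counts a hydrogen-bond donor, so these two counts alone do not predict the number here. No measurement shown here accounts for the size of this step.

Going by these compounds, whether a smaller dimethylamino group or a pyrrolidine amide on the same carbonyl carbon would give a similar step remains open, as does the result with a free carboxylic acid there. On these data alone, it is also open whether diethylamino gives a similar step when methoxy sits on the saturated chain.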